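The source may hold more compounds than are shown below. What is called first, only, known or untested is meant among the compounds shown, and "the series" means these compounds.

In a functional assay on ECa-109 cells (Homo sapiens) for cytotoxicity, read by MTT assay, with a stated time of 72 h (a lower number here means a stronger inhibitor, a higher number a weaker inhibitor), compound 1 `CC(C)=C1C(=O)N(c2ccc(Cl)cc2)N(c2ccc(Cl)cc2)C1=O` gives 42100 nM and compound 2 `O=C1C(=Cc2ccc(O)cc2)C(=O)N(c2ccc(Cl)cc2)N1c1ccc(Cl)cc1` gives 34200 nM. Compound 3 `CN(C)c1ccc(C=C2C(=O)N(c3ccc(Cl)cc3)N(c3ccc(Cl)cc3)C2=O)cc1` gives > 128000 nM, which is a limit of the assay and not a number. As far as these compounds go, its exact place therefore stays open, and the record shows it as the limit of > 128000 nM in this assay, at which 1 of the 3 values shown sits.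

Compound 4 `O=C1C(=Cc2ccc(F)cc2)C(=O)N(c2ccc(Cl)cc2)N1c1ccc(Cl)cc1` has fluoro in place of dimethylamino on an aromatic carbon, para to a large group: fluoro in place of dimethylamino on an aromatic carbon. For the measured compounds named here, the one measured step that bears on this is the change from hydroxy to dimethylamino at that same place, an at least 3.7-fold higher number from compound 2 to compound 3 (0.57 log units; beyond the scatter). Removing dimethylamino is therefore expected to give a clear step to a lower number in this assay.

The expected change is an at least 3.5-fold lower number from compound 3 to compound 4 (0.55 log units; beyond the scatter). For compound 4, the estimated value is 36000 nM, with an expected range of 14000 nM to 100000 nM.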

Compound 4, half-maximal inhibitory concentration: 35600 nM
Estimate against measurement, compound 4: 1.0-fold (0.00 log units) above, within the range that was stated.
By their numbers in this assay, from the lowest: compounds 2, 4 and 1 (each within the scatter of the next). At a limit, above all of these: compound 3.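

Putting fluoro in place of dimethylamino gives an at least 3.5-fold lower number from compound 3 to compound 4 (0.55 log units; beyond the scatter), so among these compounds the high number goes with dimethylamino at this place, not with the shared core. Fluoro and hydroxy cannot be told apart here, with a 1.0-fold higher number from compound 2 to compound 4 (0.02 log units; within the scatter). The true size of the first step stays unknown because compound 3 has only a limit of the assay and not a number: the limit of > 128000 nM in this assay, at which 1 of the 4 values shown sits.

As far as these compounds go, whether a methoxy group or a primary amine at this place would match hydroxy and fluoro or match dimethylamino remains open. The shared core alone does not settle this.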